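A few compounds are considered here, and "the series" means these few. Any claim that something is new, unique, unknown or untested is made for them only; others in the source may bear on it.

Compound 1 `COc1ccc(-n2cc(-c3ccccc3)c(-c3ccc4c(c3)NC(=O)CO4)n2)cc1` and compound 2 `O=C1COc2ccc(-c3[nH]c(-c4ccccc4)nc3-c3ccccc3)cc2N1` share a core and differ in the five-membered ring that carries the aromatic groups. In a functional assay on A549 cells (Homo sapiens) for cytotoxicity, read by colorimetric assay and MTT assay, with a stated time of 3 days, tested at 1 uM (a lower number here means a stronger effect, a higher number a weaker effect of the compound at the concentration tested), compound 1 gives 95.6%, and compound 2 gives 95.6%, level with compound 1 within the scatter, so both show only a weak effect at this concentration. Compound 3 `O=C1COc2ccc(-c3[nH]c(-c4ccc(Cl)cc4Cl)nc3-c3ccccc3)cc2N1` has not yet been measured; it differs from compound 2 by 2,4-dichlorophenyl in place of phenyl on an aromatic carbon. Among the measured compounds shown here, with no step between measured compounds to go by, the expected step in this assay is a number 5.6 percentage points lower from compound 2 to compound 3 (within the scatter), little or none beyond the scatter. Compound 3 is therefore estimated at 90%, between 70% and 100%.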

Compound 3, a percentage reported as activity, at one concentration (the size of the read-out at that concentration, not a potency): 97.4%
Beside the measured number, compound 3's estimate is 7.4 percentage points below it; the measured number falls inside the stated range.
By their numbers in this assay, from the lowest: compounds 1, 2 and 3 (each within the scatter of the next).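

Replacing phenyl with 2,4-dichlorophenyl on this aromatic carbon, between two ring nitrogen atoms, gives in this assay a number 1.8 percentage points higher from compound 2 to compound 3 (within the scatter). Here, a group with two added chlorine atoms therefore leaves the effect at the tested concentration as weak as before, with no step beyond the scatter. Nothing measured here offers an explanation for this result.

Still open, from the compounds shown here alone, is whether a different group at this carbon, such as an amine, a carboxylic acid or a longer chain, would give a clearly stronger effect. Also open, going by these compounds, is whether either chlorine alone would behave like the pair.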